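A few compounds are considered here, and "the series" means these few. Any claim that something is new, unique, unknown or untested is made for them only; others in the source may bear on it.

In a functional assay on MGC-803 cells (Homo sapiens) for antiproliferative activity, read by MTT assay, with a stated time of 72 h (on this read-out lower numbers stand for stronger inhibition and higher numbers for weaker inhibition), compound 1 `O=C(COc1ccc(C(=O)/C=C/c2ccccc2Cl)cc1)N[C@H]1CCOC1=O` gives 27100 nM.
In this assay compound 2 `O=C(COc1ccc(C(=O)/C=C/c2ccc(F)cc2)cc1)N[C@H]1CCOC1=O` gives > 64000 nM, which is a limit of the assay and not a number.

The measured step from compound 1 to compound 2 brought an at least 2.3-fold higher number from compound 1 to compound 2 (0.37 log units; beyond the scatter), so that compound 2 stands at the limit of > 64000 nM in this assay, at which 1 of the 2 values shown sits. Compound 3 `CC(C)(C)c1ccc(/C=C/C(=O)c2ccc(OCC(=O)N[C@H]3CCOC3=O)cc2)cc1` differs from compound 2 by tert-butyl in place of fluoro on an aromatic carbon. For the measured compounds named here, no measured step addresses this change; the only measured step concerns a different substitution on the same ring and shows how far such a change can move the number in this assay. Because compound 2 sits at a limit, only a rough expectation is possible, and compound 3 is expected to stay weak, with an estimated 50000 nM (15000 nM to 150000 nM). That estimate corresponds to an expected at least 1.2-fold lower number from compound 2 to compound 3 (0.10 log units; that floor lies within the scatter).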

Compound 3, half-maximal inhibitory concentration: 17200 nM
Compound 3: middle estimate off by 2.9-fold (0.46 log units), on the high side; low and high end bracket the measured number.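

In this assay, moving from 4-fluorophenyl to 4-(tert-butyl)phenyl brought an at least 3.7-fold lower number from compound 2 to compound 3 (0.57 log units; beyond the scatter), so the change on this aromatic carbon, para to a large group, can move the number beyond the scatter. Compound 2 stands at a limit of the assay and not at a number, so the size of this step is only a floor: the limit of > 64000 nM in this assay, at which 1 of the 3 values shown sits.

Replacing 2-chlorophenyl with 4-(tert-butyl)phenyl brought a 1.6-fold lower number from compound 1 to compound 3 (0.20 log units; within the scatter), which lies within the scatter, so compound 1 and compound 3 cannot be told apart here.

The compounds shown leave open how an amine, a carboxylic acid or a methoxy group would read on this same aromatic carbon. They also leave open whether a smaller chain such as methyl or isopropyl in place of tert-butyl would give a measurable number in this assay.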